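The source may hold more compounds than are shown below. What is called first, only, known or untested is meant among the compounds shown, and "the series" means these compounds.

Three compounds share one core and differ only in the group carried on the amide-type nitrogen of the side chain. Compound 1 `COC(=O)[C@@H](C)NC(=O)Cn1cc(C2=C(c3c[nH]c4ccccc34)C(=O)N(C)C2=O)c2ccccc21` gives 21400 nM in a functional assay on HCT-8 cells (Homo sapiens) for cytotoxicity, read by MTT assay, with a stated time of 24 h; on this read-out lower numbers stand for stronger inhibition and higher numbers for weaker inhibition. Compound 2 `COC(=O)CCNC(=O)Cn1cc(C2=C(c3c[nH]c4ccccc34)C(=O)N(C)C2=O)c2ccccc21` gives 50900 nM. Compound 3 `COC(=O)[C@@H](CC(C)C)NC(=O)Cn1cc(C2=C(c3c[nH]c4ccccc34)C(=O)N(C)C2=O)c2ccccc21` gives 37800 nM. On these numbers compound 3 stands second highest of three. Its step from compound 2 reads a 1.3-fold lower number from compound 2 to compound 3 (0.13 log units; within the scatter), and its step from compound 1 reads a 1.8-fold higher number from compound 1 to compound 3 (0.25 log units; within the scatter), so these pairs cannot be told apart. Among the measured compounds shown here, the only step beyond the scatter is a 2.4-fold higher number from compound 1 to compound 2 (0.38 log units; beyond the scatter).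

Compound 4 `COC(=O)C[C@@H](NC(=O)Cn1cc(C2=C(c3c[nH]c4ccccc34)C(=O)N(C)C2=O)c2ccccc21)C(=O)OC` is not yet measured. It differs from compound 3 by methoxycarbonyl in place of isopropyl on a saturated chain carbon, two bonds along the chain from an amide-type nitrogen and a carbonyl carbon. The closest measured comparison is a 1.8-fold higher number from compound 1 to compound 3 (0.25 log units; within the scatter), where a group was placed on that same chain carbon without a change beyond the scatter. All three measured numbers sit in a narrow band, so for compound 4 no step beyond the scatter is expected. The expected step is a 1.1-fold lower number from compound 3 to compound 4 (0.03 log units; within the scatter). Compound 4 is estimated at 35000 nM, with a range from 15000 nM to 80000 nM.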

Compound 4, half-maximal inhibitory concentration: 23400 nM
Compound 4: the middle estimate sits 1.5-fold (0.17 log units) above what was measured; the measured number falls inside the stated range.
By their numbers in this assay, from the lowest: compounds 1, 4, 3 and 2 (each within the scatter of the next, the first and the last beyond it).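

Methoxycarbonyl on the saturated chain carbon, two bonds along the chain from an amide-type nitrogen and a carbonyl carbon, cannot be told apart from isopropyl there: a 1.6-fold lower number from compound 3 to compound 4 (0.21 log units; within the scatter) stays within the scatter, even though the entering group counts two hydrogen-bond acceptors and the leaving one none. The same holds against hydrogen at that carbon, with a 1.1-fold higher number from compound 1 to compound 4 (0.04 log units; within the scatter). Among the compounds shown here, the one new step beyond the scatter, and a modest one, is a 2.2-fold lower number from compound 2 to compound 4 (0.34 log units; beyond the scatter), yet it is no clean rule for the chain, since compound 3 also differs from compound 2 there and a 1.3-fold lower number from compound 2 to compound 3 (0.13 log units; within the scatter) stays within the scatter.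

Nothing given here accounts for these numbers. Still open, as far as these compounds go, is whether a carboxylic acid, an amine or a longer chain at this carbon would shift the number beyond the scatter.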